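Chloro next to the ring nitrogen in a diarylalkyne series

A few compounds are considered here, and "the series" means these few. Any claim that something is new, unique, unknown or untested is made for them only; others in the source may bear on it.

Compound 1, `Fc1cccc(F)c1C#Cc1cncc2ccccc12`, gives 16.5% in a functional assay on LS174T cells (Homo sapiens) for inhibition, with a stated time of 4 days, tested at 1 uM (a lower number here means a weaker effect, a higher number a stronger effect of the compound at the concentration tested), a value that sits within the scatter of compound 2, `Fc1cccc(F)c1C#Cc1ccc2cnccc2c1`, which gives 11.6% in this assay. For the measured compounds named here, no step between measured compounds is known. Compound 3, `Fc1cccc(F)c1C#Cc1cnc(Cl)c2ccccc12`, carries the change chloro in place of hydrogen on an aromatic carbon relative to compound 1. Going by the values given here, no measured step tells what this change does, so the step from compound 1 to compound 3 is expected to be small and in no sure direction, with an expected a number 3.5 percentage points higher from compound 1 to compound 3 (within the scatter). Compound 3 is expected to give 20% in this assay, with an estimated range from 5% to 40%.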

Compound 3, a percentage reported as inhibition, at one concentration (the size of the read-out at that concentration, not a potency): 48.1%
Compound 3: the middle estimate sits 28.1 percentage points below what was measured; measured number outside the range, above it.
By their numbers in this assay, from the lowest: compounds 2 and 1 (each within the scatter of the next); then compound 3.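

Chloro in place of hydrogen on an aromatic carbon, next to the ring nitrogen, gives the only step in the series that lies beyond the scatter in this assay, with a number 31.6 percentage points higher from compound 1 to compound 3 (beyond the scatter) as a large step. This position therefore responds to substitution, which compound 1 and compound 2 alone could not show. No measurement shown bears on the reason for this rise.

The compounds shown leave open whether the rise is specific to chloro or would also appear with fluoro, methoxy, an amine or a nitrile at this place. From the compounds shown here alone, whether chloro has a similar effect on the core of compound 2 also remains open.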